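Dropping the bromo from a sulfonyl-linked oxadiazole

The compounds below may be only part of what the source reports. "The series", "measured", "known", "first", "only" and "open" are said of these compounds alone.

Compound 1: `CC(O)(CS(=O)(=O)c1ccc(Br)cc1)c1nc(-c2ccc([N+](=O)[O-])c(C(F)(F)F)c2)no1` — > 100000 nM
Compound 2: `CC(O)(CS(=O)(=O)c1ccc(Br)cc1)c1nc(-c2ccccc2)no1` — > 100000 nM
Compound 3: `CC(O)(CSc1ccc(Cl)cc1)c1nc(-c2ccc(F)c(Cl)c2)no1` — 500 nM

The three compounds share a core and were tested in a functional assay on DU-145 cells (Homo sapiens) for cytotoxicity, read by MTT assay; a lower number here means a stronger inhibitor, a higher number a weaker inhibitor. Compound 1 gives only a limit there, namely > 100000 nM. Compound 2 likewise returns a limit, > 100000 nM. Compound 3, in contrast, gives a measured number, 500 nM. Compound 1 therefore stands at the weak end of what is shown, together with compound 2, a position described by the limit of > 100000 nM in this assay, at which 2 of the 3 values shown sit.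

The next compound, compound 4 (`CC(O)(CS(=O)(=O)c1ccccc1)c1nc(-c2ccc([N+](=O)[O-])c(C(F)(F)F)c2)no1`), has not yet been measured. Its difference from compound 1 is hydrogen in place of bromo on an aromatic carbon — hydrogen in place of bromo on an aromatic carbon, para to a large group. Among the compounds with values here, no measured pair in this set isolates such a change, so no step size can be read from the data.

Compound 2 already shows that a phenylsulfonyl compound of this core can sit at the limit, and compound 1 sits there as well. Compound 4 is therefore expected to remain at the limit, with an estimate of 100000 nM and a range from 30000 nM to 300000 nM. The expected step of a number no higher from compound 1 to compound 4 (the limit leaves the size open) is thus none beyond the scatter.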

Compound 4, half-maximal inhibitory concentration: > 100000 nM
Compound 4 was reported as a limit; the forecaster's own chance of this, stated with the estimate: 80%; the middle value sits exactly at the limit.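

Compound 4, like compound 1, returns only a limit in this assay, so no step between the two can be read for hydrogen in place of bromo: the limit of > 100000 nM in this assay, at which 3 of the 4 values shown sit.

The compounds shown leave open whether this change has any effect on a compound of the shared core that gives a measured number.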